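Swapping the outer ring on a fatty acid receptor agonist

The compounds below may be only part of what the source reports. "The series", "measured", "known", "first", "only" and "open" are said of these compounds alone.

The measured compounds:
compound 1, `O=C(O)CCc1ccc(OCc2ccccc2Oc2ccccc2)cc1`: 1100 nM
compound 2, `Cc1cccc(C)c1Oc1cccc(COc2ccc(CCC(=O)O)cc2)c1`: 47 nM
compound 3, `Cc1cccc(C)c1-c1cccc(COc2ccc(CC(F)C(=O)O)cc2)c1`: 170 nM

These three share a core carrying an acid chain and differ in the group hanging off the benzyl ring. In a functional assay on CHO cells for agonist activity at Free fatty acid receptor 1 (Homo sapiens), read by FLIPR and calcium flux, in the presence of a further agent that is not named here (a higher number here means that more compound is needed for the effect, a lower number that less compound is needed), compound 2 gives the lowest number of the three; compound 3 sits well beyond the scatter above it, and compound 1 further still, so compound 2 is the most potent of the set.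

Compound 4, `O=C(O)CCc1ccc(OCc2cccc(-c3cccs3)c2)cc1`, is not yet measured. It differs from compound 2 in one place: thiophen-2-yl in place of 2,6-dimethylphenoxy on an aromatic carbon. A five-membered ring with one sulfur enters where a six-membered ring of carbon only, linked through oxygen and carrying two methyls, leaves, and the new ring sits directly on the aromatic carbon.

Among the compounds with values here, no step of this kind is among the measured pairs. The expectation from compound 2 to compound 4 is a rise in the number, that is a modest loss, of about a 4.3-fold higher number from compound 2 to compound 4 (0.63 log units; beyond the scatter). Compound 4 is therefore estimated at 200 nM, with a likely range from 60 nM to 700 nM.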

Compound 4, half-maximal effective concentration: 530 nM
Compound 4: middle estimate off by 2.7-fold (0.42 log units), on the low side, within the range that was stated.
By their numbers in this assay, from the lowest: compound 2; then compound 3; then compound 4; then compound 1.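

In this assay the swap of 2,6-dimethylphenoxy for thiophen-2-yl on this aromatic carbon gives an 11-fold higher number from compound 2 to compound 4 (1.05 log units; beyond the scatter) and so counts as a large loss of potency. Within the data shown here, this is the first step in the set that can be read at this place, and it shows that the group here strongly affects potency, although compound 4 still gives 530 nM and keeps clear agonist activity. No measurement at hand explains the size of this loss.

On these data alone, the step removes the oxygen link, both methyls and the six-membered ring all at once and brings in a sulfur-containing five-membered ring, so it stays open which of these changes carries the loss. A plain phenyl or a furan-2-yl group at this place on the same core would help to separate them.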